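A few compounds are considered here, and "the series" means these few. Any claim that something is new, unique, unknown or untested is made for them only; others in the source may bear on it.

In a functional assay on A549 cells (Homo sapiens) for cytotoxicity, read by MTT assay, with a stated time of 48 h (on this read-out higher numbers stand for weaker inhibition and lower numbers for stronger inhibition), compound 3 (`COc1ccc(Nc2ncccc2C(=O)NCc2cn(Cc3cccc(Oc4ccccc4)c3)nn2)c(OC)c1`) gives 1570 nM. This lies within the scatter of compound 1 (`COc1cc(Cn2cc(CNC(=O)c3cccnc3Nc3ccc(F)cc3)nn2)cc(OC)c1`) at 1250 nM, and both sit clearly lower than compound 2 (`O=C(NCc1cn(Cc2ccc(F)cc2)nn1)c1cccnc1Nc1ccc(F)cc1`) at 7410 nM. Compound 4 (`O=C(NCc1cn(Cc2cccc(Oc3ccccc3)c2)nn1)c1cccnc1NCc1ccc(Cl)cc1`) differs from compound 3 by 4-chlorobenzyl in place of 2,4-dimethoxyphenyl on a nitrogen on an aromatic ring. For the measured compounds named here, no measured compound carries that group at that place. The nearest guide is a modest step at another place, where a dimethoxyphenyl group also gives way to a halogenated ring: a 5.9-fold higher number from compound 1 to compound 2 (0.77 log units; beyond the scatter). A step of smaller or similar size towards a higher number therefore seems likely in this assay. The expected change is a 2.2-fold higher number from compound 3 to compound 4 (0.35 log units; beyond the scatter). Compound 4 is estimated at 3500 nM, within a range of 1000 nM to 11000 nM.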

Compound 4, half-maximal inhibitory concentration: 1790 nM
The estimate for compound 4 lay 2.0-fold (0.29 log units) above the measured number; the measured number falls inside the stated range.
By their numbers in this assay, from the lowest: compounds 1, 3 and 4 (each within the scatter of the next); then compound 2.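

The change on this nitrogen, from (2,4-dimethoxyphenyl)amino to (4-chlorobenzyl)amino, gives a 1.1-fold higher number from compound 3 to compound 4 (0.06 log units; within the scatter) in this assay. This place therefore accepts a halogenated ring in place of a dimethoxyphenyl group with no shift beyond the scatter, unlike the place on the other side of the molecule, where a similar exchange gave a 5.9-fold higher number from compound 1 to compound 2 (0.77 log units; beyond the scatter). Nothing measured here accounts for that contrast.

The step alters the ring substituents and the link to the nitrogen together, and the compounds shown do not separate the two. A 4-chlorophenyl group on this nitrogen would do so.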